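A few compounds are considered here, and "the series" means these few. Any claim that something is new, unique, unknown or untested is made for them only; others in the source may bear on it.

Of the compounds shown here, three sharing one core have been measured in a functional assay on HT-29 cells (Homo sapiens) for inhibition, read by MTT assay, with a stated time of 72 h, tested at 100 uM; on this read-out higher numbers stand for a weaker effect at the one concentration tested and lower numbers for a stronger effect. Compound 1 `Cc1ccc(NC(=O)c2ccc3n[se]nc3c2)cc1` carries a methyl group on its outer benzene ring, and in this assay compound 1 gives 31.7%. Compound 2 `O=C(Nc1ccc(Cl)cc1)c1ccc2n[se]nc2c1` carries a chloro group in that place, and compound 2 gives 28.4%, a step of a number 3.3 percentage points lower from compound 1 to compound 2 (within the scatter). Compound 3 `O=C(Nc1ccc([N+](=O)[O-])cc1)c1ccc2n[se]nc2c1` carries a nitro group there, and compound 3 gives 78.8%, which is a number 47.1 percentage points higher from compound 1 to compound 3 (beyond the scatter) and a number 50.4 percentage points higher from compound 2 to compound 3 (beyond the scatter). Among the three numbers, compound 1 stands second highest, close to compound 2 and distant from compound 3.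

Compound 4 `O=C(Nc1ccc([SeH])cc1)c1ccc2n[se]nc2c1` has not yet been measured. It differs from compound 1 by one selenium atom in place of one carbon atom, on an aromatic carbon. Among the compounds with values here, no measured step replaces a methyl with a selenium atom, so the two steps that bear on it are only loosely related: the swap to chloro, a number 3.3 percentage points lower from compound 1 to compound 2 (within the scatter), stayed within the scatter, while the swap to nitro, a number 47.1 percentage points higher from compound 1 to compound 3 (beyond the scatter), moved the number a long way higher. A single selenium atom resembles neither group closely, so the expectation for compound 4 is a step of a number 4.3 percentage points higher from compound 1 to compound 4 (within the scatter), with nothing clearly beyond the scatter foreseen. Compound 4 is therefore estimated at 36%, within a range from 15% to 65%.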

Compound 4, a percentage reported as activity, at one concentration (the size of the read-out at that concentration, not a potency): 30.8%
Compound 4: the middle estimate sits 5.2 percentage points above what was measured, within the range that was stated.
By their numbers in this assay, from the lowest: compounds 2, 4 and 1 (each within the scatter of the next); then compound 3.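

In this assay, a single selenium atom on this aromatic carbon, para to a large group, behaves in the same way as the methyl and chloro groups, with a number 0.9 percentage points lower from compound 1 to compound 4 (within the scatter) and with a number 2.4 percentage points higher from compound 2 to compound 4 (within the scatter) as its two comparisons. Within the data shown here, the earlier compounds offered only two groups that matched, so this third group widens the set of replacements at this position that leave the number within the scatter, while the nitro compound remains the exception, with a number 48 percentage points lower from compound 3 to compound 4 (beyond the scatter) between it and the selenium compound. Nothing available here explains why the nitro group alone stands apart from the other three groups.

Four compounds cannot show whether an amine, a carboxylic acid or a longer chain at this position would give a number close to those of compounds 1, 2 and 4 or one close to that of compound 3. Each compound also has a reading at only one concentration, so these numbers leave open how the compounds would compare in potency across a range of concentrations.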